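The source may hold more compounds than are shown below. What is called first, only, known or untested is meant among the compounds shown, and "the series" means these compounds.

In a functional assay on HeLa cells (Homo sapiens) for cytotoxicity, read by MTT assay (on this read-out higher numbers stand for weaker inhibition and lower numbers for stronger inhibition), compound 1 `CC(C)=CC[C@@H](OC(=O)CCO)C1=CC(=O)c2c(O)ccc(O)c2C1=O` gives 67600 nM, compound 2 `CC(C)=CC[C@@H](OC[C@H](C)O)C1=CC(=O)c2c(O)ccc(O)c2C1=O` gives 40300 nM and compound 3 `CC(C)=CC[C@@H](OC(=O)C1CCOC1)C1=CC(=O)c2c(O)ccc(O)c2C1=O` gives 73500 nM. Compound 3 holds the highest of the three numbers, but the steps of a 1.1-fold higher number from compound 1 to compound 3 (0.04 log units; within the scatter) and a 1.8-fold higher number from compound 2 to compound 3 (0.26 log units; within the scatter) both lie within the scatter, so no order among the three can be read from them. Compound 4 `CCCCC(C)(O)CC(=O)O[C@H](CC=C(C)C)C1=CC(=O)c2c(O)ccc(O)c2C1=O` differs from compound 3 in one place: 2-hydroxy-2-methylhexyl in place of oxolan-3-yl on a carbonyl carbon. The step of a 1.1-fold higher number from compound 1 to compound 3 (0.04 log units; within the scatter) also exchanged the group on the carbonyl carbon and stayed within the scatter, as did a 1.7-fold lower number from compound 1 to compound 2 (0.22 log units; within the scatter); on that basis no step beyond the scatter is expected, a 1.1-fold lower number from compound 3 to compound 4 (0.02 log units; within the scatter). Compound 4 is therefore estimated at 70000 nM, with a range from 30000 nM to 160000 nM.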

Compound 4, half-maximal inhibitory concentration: 60600 nM
The estimate for compound 4 lay 1.2-fold (0.06 log units) above the measured number; measured number inside the range.
By their numbers in this assay, from the lowest: compounds 2, 4, 1 and 3 (each within the scatter of the next).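

In this assay the step of a 1.2-fold lower number from compound 3 to compound 4 (0.08 log units; within the scatter) shows that the open 2-hydroxy-2-methylhexyl can stand in place of the ring of oxolan-3-yl on a carbonyl carbon with no readable change. The same holds for a 1.5-fold higher number from compound 2 to compound 4 (0.18 log units; within the scatter) and for a 1.1-fold lower number from compound 1 to compound 4 (0.05 log units; within the scatter) so the four compounds stay without an order, even with this larger group. On these data alone, whether an amine or a carboxylic acid on this chain would carry the number beyond the scatter remains open. Nothing at hand gives a reason for this lack of change.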